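The compounds below may be only part of what the source reports. "The series", "measured", "known", "first", "only" and "open" are said of these compounds alone.

Compound 1 `CC(=O)Nc1cc(C(=O)O)nn1Cc1cc(Br)ccc1OCc1ccccc1`: < 2000 nM, a limit of the assay.
Compound 2 `Cc1cn(Cc2cc(Br)ccc2OCc2ccccc2)nc1C(=O)O`: 1350 nM.
Compound 3 `O=C(O)c1cncn1Cc1cc(Br)ccc1OCc1ccccc1`: < 2000 nM, a limit of the assay.

In a functional assay on CHO-K1 cells for antagonist activity at prostaglandin E2 receptor EP1 subtype (Homo sapiens), read by FLIPR (on this read-out lower numbers stand for stronger inhibition and higher numbers for weaker inhibition), compound 3 gives only < 2000 nM, which is a limit rather than a measured number. Compound 1 likewise stands at < 2000 nM, a limit, so that the limit of < 2000 nM in this assay, at which 2 of the 3 values shown sit, covers most of what is known here. In this assay compound 2 gives 1350 nM. Compound 4 `O=C(O)c1cn(Cc2cc(Br)ccc2OCc2ccccc2)cn1` has the same atoms as compound 3 joined differently: 4-carboxy-1H-imidazol-1-yl in place of 5-carboxy-1H-imidazol-1-yl on a saturated chain carbon bound to an aromatic carbon. Within the data shown here, no measured pair shows what such a change does. The step from compound 3 to compound 4 is expected to be a step that the limit leaves unreadable from compound 3 to compound 4, no more than the usual scatter in either direction. Compound 4 is therefore estimated at 1500 nM, within a range from 400 nM to 5000 nM.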

Compound 4, inhibition constant: < 2000 nM
Compound 4: a limit, no number; the forecaster's own chance of this, stated with the estimate: 40%; the middle value is on the limit's open side.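

Compound 3 and compound 4 both stand only at a limit in this assay, so no step between them can be read, and the same holds more widely: the limit of < 2000 nM in this assay, at which 3 of the 4 values shown sit.

The compounds shown leave open whether 4-carboxy-1H-imidazol-1-yl in place of 5-carboxy-1H-imidazol-1-yl changes inhibition at all, and by how much.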